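The source may report more compounds than this note shows. Statements on the series, on what has been measured and on what is new or still open speak of the compounds shown alone.

Compound 1: `N#Cc1c(NCc2ccccc2)c(F)c2nc(N)nc(N)c2c1F`; 11 ug/mL
Compound 2: `N#Cc1c(NCc2ccccc2)c(Cl)c2nc(N)nc(N)c2c1NCc1ccccc1`; 3.7 ug/mL

Going by the values given here, in a functional assay on SK-OV-3 cells (Homo sapiens) for cytotoxicity, read by MTT assay (a lower number here means a stronger inhibitor, a higher number a weaker inhibitor), compound 2 gives 3.7 ug/mL, the lowest of the two numbers so far, and compound 1 gives 11 ug/mL, a number that lies beyond the scatter above it. Among the compounds with values here, compound 1 and compound 2 differ in more than one place, so their two values show only that compound 2 is the stronger of the pair. Compound 3, `N#Cc1c(NCc2ccccc2)c(F)c2nc(N)nc(N)c2c1NCc1ccccc1`, has not yet been measured in this assay. It differs from compound 2 by fluoro in place of chloro on an aromatic carbon. Within the data shown here, no measured pair shows this change on its own, so the numbers give no direct guide. One halogen replaces another, and the account expects only a small step, within the scatter, in either direction. Compound 3 is therefore expected to give about 5 ug/mL, within a range from 2 ug/mL to 12 ug/mL. The expected step is a 1.4-fold higher number from compound 2 to compound 3 (0.13 log units; within the scatter).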

Compound 3, half-maximal inhibitory concentration: 2.5 ug/mL
Compound 3: the middle estimate sits 2.0-fold (0.30 log units) above what was measured; low and high end bracket the measured number.
By their numbers in this assay, from the lowest: compounds 3 and 2 (each within the scatter of the next); then compound 1.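

In this assay, fluoro in place of chloro on the aromatic carbon para to a benzylamino group gives a 1.5-fold lower number from compound 2 to compound 3 (0.17 log units; within the scatter), so compound 2 and compound 3 cannot be told apart, and swapping one of these halogens for the other at this position has no readable effect. Going by these compounds alone, the other single change, benzylamino in place of fluoro on an aromatic carbon, gives a 4.4-fold lower number from compound 1 to compound 3 (0.64 log units; beyond the scatter), the only step of the two that lies beyond the scatter. Of these two changes, then, only the gain of the second benzylamino group moves the number.

Nothing available explains either step. Going by these compounds, whether an amine, a longer chain or a plain hydrogen in place of the halogen would keep the number of compound 3 remains open.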